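Series notes: amine-to-amide swap at the side-chain terminus

The source may hold more compounds than are shown below. What is called first, only, known or untested is meant among the compounds shown, and "the series" means these compounds.

Measured compounds in an assay on adrenal medulla for inhibition of Vasopressin V2 receptor (Rattus norvegicus), read by radioligand binding; a higher number here means a weaker inhibitor, a lower number a stronger inhibitor:
- compound 1, `CN(C)C1CCN(C(=O)CCCOc2cc(C(=O)N3CCCCc4sccc43)ccc2NC(=O)c2ccccc2-c2ccccc2)CC1`, gives 3 nM.
- compound 2, `CN(C)C1CCN(C(=O)COc2cc(C(=O)N3CCCCc4sccc43)ccc2NC(=O)c2ccccc2-c2ccccc2)CC1`, gives 4 nM.
- compound 3, `CN1CCCN(CCCOc2cc(C(=O)N3CCCCc4sccc43)ccc2NC(=O)c2ccccc2-c2ccccc2)CC1`, is reported only as a limit, < 1 nM, and not as a number.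

Compound 1 has the lowest of the two numbers shown; compound 2 sits within the scatter of it, so no order between the two is claimed. The third value is a limit, as stated in the limit of < 1 nM in this assay, at which 1 of the 3 values shown sits.

Compound 4, `CN1CCCN(C(=O)CCCOc2cc(C(=O)N3CCCCc4sccc43)ccc2NC(=O)c2ccccc2-c2ccccc2)CC1`, differs from compound 1 in one place: 4-methyl-1,4-diazepan-1-yl in place of 4-(dimethylamino)piperidin-1-yl on a carbonyl carbon. The measured steps that touch the same terminus, an at least 3.0-fold lower number from compound 1 to compound 3 (0.47 log units; beyond the scatter) and an at least 4.0-fold lower number from compound 2 to compound 3 (0.60 log units; beyond the scatter), both move the number down, but each of them also removes the carbonyl, which compound 4 keeps. The bearing of those steps on compound 4 is therefore only partial, and a smaller step downward is expected here.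

Compound 4 is estimated at 1.5 nM, within 0.5 nM to 4 nM, an expected step of a 2.0-fold lower number from compound 1 to compound 4 (0.30 log units; within the scatter).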

Compound 4, half-maximal inhibitory concentration: 3 nM
The estimate for compound 4 lay 2.0-fold (0.30 log units) below the measured number; the range from low to high includes it.
By their numbers in this assay, from the lowest: compounds 1, 4 and 2 (each within the scatter of the next). At a limit, below all of these: compound 3.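

In this assay, with the carbonyl kept, the exchange of rings gives no change at the digits printed from compound 1 to compound 4 (within the scatter), so on this carbonyl carbon 4-methyl-1,4-diazepan-1-yl and 4-(dimethylamino)piperidin-1-yl are not told apart, and the ring exchange alone does not reproduce the earlier step of an at least 3.0-fold lower number from compound 1 to compound 3 (0.47 log units; beyond the scatter). For the compounds shown here, with 4-methyl-1,4-diazepan-1-yl held constant, the carbonyl form shows an at least 3.0-fold higher number from compound 3 to compound 4 (0.47 log units; beyond the scatter), the first step that keeps this ring on both sides, though its size is bounded on one side only: the limit of < 1 nM in this assay, at which 1 of the 4 values shown sits. The step of a 1.3-fold lower number from compound 2 to compound 4 (0.12 log units; within the scatter) changes both the ring and the chain and still shows no separation among the amides.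

Still open, on these data alone, is whether 4-(dimethylamino)piperidin-1-yl, attached directly to the chain without the carbonyl, would match compound 3. Also open, as far as these compounds go, is whether a morpholine on this carbonyl carbon, with no second amine, would stay level with compound 1 and compound 4.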